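A few compounds are considered here, and "the series" means these few. Any claim that something is new, unique, unknown or untested is made for them only; others in the source may bear on it.

Measured compounds in this series:
Compound 1 `COc1ccc(-c2cc3ccccc3nc2C=O)cc1` — > 10000 nM (a limit of the assay)
Compound 2 `COc1ccc(-c2cc3ccccc3nc2/C=C/C(=O)c2ccccc2)cc1` — 7410 nM
Compound 3 `COc1ccc(C(=O)/C=C/c2nc3ccccc3cc2-c2ccc(OC)cc2)cc1` — 8500 nM
Compound 4 `COc1ccc(-c2cc3ccccc3nc2/C=C/C(=O)c2cccs2)cc1` — not yet measured

In a functional assay on A549 cells (Homo sapiens) for antiproliferative activity, read by XTT assay, with a stated time of 72 h (on this read-out higher numbers stand for weaker inhibition and lower numbers for stronger inhibition), compound 1 gives > 10000 nM, which is a limit of the assay and not a number. Compound 2 gives 7410 nM in this assay. Compound 3 gives 8500 nM, and the step of a 1.1-fold higher number from compound 2 to compound 3 (0.06 log units; within the scatter) lies within the scatter, so compound 3 sits alongside compound 2 rather than apart from it; the remaining value in the series is the limit of > 10000 nM in this assay, at which 1 of the 3 values shown sits, and compound 3 holds the higher of the two numbers that are numbers.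

Compound 4 differs from compound 3 by thiophen-2-yl in place of 4-methoxyphenyl on a carbonyl carbon. Within the data shown here, no measured step alters the group on the carbonyl carbon itself; the only measured step, a 1.1-fold higher number from compound 2 to compound 3 (0.06 log units; within the scatter), changes the substituent on that same aryl ring and stays within the scatter, which suggests tolerance at this position but gives no direct reading for a five-membered ring with one hetero atom. The step from compound 3 to compound 4 is therefore expected to be a 1.2-fold lower number from compound 3 to compound 4 (0.08 log units; within the scatter), no larger than the scatter. Compound 4 is estimated at 7000 nM, with a range from 2500 nM to 20000 nM in this assay.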

Compound 4, half-maximal inhibitory concentration: 920 nM
Compound 4: middle estimate off by 7.6-fold (0.88 log units), on the high side; the measured number lies below the stated range.
By their numbers in this assay, from the lowest: compound 4; then compounds 2 and 3 (each within the scatter of the next). At a limit, above all of these: compound 1.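

In this assay the group on the carbonyl carbon proves to matter, with a 9.2-fold lower number from compound 3 to compound 4 (0.97 log units; beyond the scatter) and an 8.1-fold lower number from compound 2 to compound 4 (0.91 log units; beyond the scatter), whereas the methoxy on that aryl ring had left the number within the scatter. The number therefore responds to exchanging the ring itself, a six-membered aromatic ring of carbon only for a five-membered aromatic ring with 1 hetero atom, and not to the one substituent tried so far on the phenyl ring. With 2-((thiophen-2-yl)carbonyl)ethenyl in place of formyl the reading is an at least 10-fold lower number from compound 1 to compound 4 (1.03 log units; beyond the scatter), and this step rests on a limit of the assay for compound 1, not on a number: the limit of > 10000 nM in this assay, at which 1 of the 4 values shown sits.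

A single five-membered ring cannot separate the sulfur from the ring size, so furan-2-yl or thiophen-3-yl on the carbonyl carbon remains the open comparison. Also open, as far as these compounds go, is how much of the gain holds with thiophen-2-yl kept and the rest varied, for instance a saturated ethane chain in place of the ethenyl link or an amine in place of the methoxy on the 4-methoxyphenyl ring of the shared core.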